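This account rests on a few compounds, and the source may have more. Where it says the series, first, only, none or still open, it means among the compounds named here.

Measured so far:
compound 1 `Clc1ccc2c(O/N=C(/C=C/c3ccc(OCc4ccccc4Cl)cc3)\C=C\c3ccccn3)ncnc2c1`: 84.7%
compound 2 `Clc1ccccc1COc1ccc(/C=C/C(/C=C/c2ccccn2)=N/Oc2ncnc3ccccc23)cc1`: 96.9%

Among the measured compounds shown here, in a functional assay on SMMC-7721 cells (Homo sapiens) for inhibition, read by MTT assay, with a stated time of 72 h, tested at 10 uM (on this read-out higher numbers stand for a stronger effect at the one concentration tested and lower numbers for a weaker effect), compound 1 stands lowest of the two numbers, with compound 2 nearest, and the one measured step, a number 12.2 percentage points higher from compound 1 to compound 2 (beyond the scatter), concerns hydrogen in place of chloro on an aromatic carbon. Compound 3 `Cc1cccc(COc2ccc(/C=C/C(/C=C/c3ccccn3)=N/Oc3ncnc4cc(Cl)ccc34)cc2)c1` differs from compound 1 elsewhere: 3-methylphenyl in place of 2-chlorophenyl on a saturated chain carbon bound to an oxygen on an aromatic ring. For the measured compounds named here, no measured step touches this part of the molecule, so nothing here speaks for a shift either way, and the step is expected to stay within the scatter, a number 0.3 percentage points higher from compound 1 to compound 3 (within the scatter). Compound 3 is therefore estimated at 85%, in a range from 65% to 100%, pending the read-out.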

Compound 3, a percentage reported as inhibition, at one concentration (the size of the read-out at that concentration, not a potency): 95.6%
Compound 3: middle estimate off by 10.6 percentage points, on the low side; the range from low to high includes it.
By their numbers in this assay, from the lowest: compound 1; then compounds 3 and 2 (each within the scatter of the next).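

In this assay, 3-methylphenyl in place of 2-chlorophenyl on a saturated chain carbon bound to an oxygen on an aromatic ring gives a number 10.9 percentage points higher from compound 1 to compound 3 (beyond the scatter), a modest step. This part of the molecule, untouched by the earlier step, therefore also moves the read-out. No measured evidence available here accounts for this step.

On these data alone, both the chloro and the methyl change in this step, so their separate contributions remain open. Also open, as far as these compounds go, is how an amine or a carboxylic acid on this ring would read out.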